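The source may report more compounds than this note shows. Statements on the series, on what has been measured and on what is new or still open speak of the compounds shown alone.

Measured compounds in a functional assay on HeLa cells (Homo sapiens) for inhibition, read by MTT assay, with a stated time of 4 days; on this read-out lower numbers stand for stronger inhibition and higher numbers for weaker inhibition:

Compound 1, `COc1ccc(C(=NNC(=O)NNC(=O)NCCCC(C)Nc2cc(OC)cc3cccnc23)c2ccc(OC)cc2)cc1`, gives 50000 nM.
Compound 2, `COc1cc(NC(C)CCCNC(=O)NNC(=O)N(CCO)CCO)c2ncccc2c1`, gives > 250000 nM.
Compound 3, `COc1ccc(/C(=N/NC(=O)NCCCC(C)Nc2cc(OC)cc3cccnc23)c2ccccc2)cc1`, gives 129000 nM.

Of the three, compound 1 and compound 3 return actual numbers on the read-out. Compound 2 does not: its entry is only a limit of this assay, not a measured concentration. That is where compound 2 stands among the values shown, described by the limit of > 250000 nM in this assay, at which 1 of the 3 values shown sits.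

The step under consideration leads from compound 2 to compound 4, `COc1cc(NC(C)CCCNC(=O)NNC(=O)NC(CO)(CO)CO)c2ncccc2c1`, which is not yet measured. The two differ at a single place: (2-hydroxy-1,1-bis(hydroxymethyl)ethyl)amino in place of bis(2-hydroxyethyl)amino on a carbonyl carbon. Both the group that leaves and the group that enters are small, uncharged chains bearing hydroxyl groups, and the rest of the molecule is unchanged.

For the measured compounds named here, no pair of measured compounds that differ in just one place is available, so the size of this step cannot be read from the data. Compound 1 and compound 3 offer no guidance on this particular change either, since they carry a different tail altogether. The expectation is that the change from compound 2 to compound 4 does not move the read-out beyond the usual scatter, and that compound 4, like compound 2, is most likely to return only a limit rather than a number; the step implied by this estimate is a step that the limit leaves unreadable from compound 2 to compound 4.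

For compound 4 the value expected in this assay is 300000 nM, with a range from 120000 nM to 700000 nM.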

Compound 4, half-maximal inhibitory concentration: > 250000 nM
Compound 4 ended at the assay's limit (the forecaster's own chance of this, stated with the estimate: 70%); the middle value lies beyond the limit too.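

In this assay neither compound 2 nor compound 4 gives an actual number, so no step between them can be read; both entries are limits of the assay: the limit of > 250000 nM in this assay, at which 2 of the 4 values shown sit.

As far as these compounds go, whether (2-hydroxy-1,1-bis(hydroxymethyl)ethyl)amino and bis(2-hydroxyethyl)amino on this carbonyl carbon differ at all in their effect on inhibition remains open.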